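The source may hold more compounds than are shown below. What is called first, only, known or untested is meant among the compounds shown, and "the series" means these compounds.

Of the compounds shown here, three built on a shared core have been tested in a functional assay on U-87MG ATCC cells for inhibition, with U-87 MG (Homo sapiens) as the target, read by MTT assay, with a stated time of 72 h; on this read-out lower numbers stand for stronger inhibition and higher numbers for weaker inhibition. Compound 1 `COc1ccccc1-c1csc2cnc(Nc3ccc(NC(=O)C4CCNCC4)cc3)nc12` gives 1060 nM in this assay. Compound 2 `COc1ccccc1-c1csc2cnc(Nc3ccc(NC(=O)[C@@H]4CCCNC4)cc3)nc12` gives 360 nM. These two structures differ in one place, and the step between them is a 2.9-fold lower number from compound 1 to compound 2 (0.47 log units; beyond the scatter). Compound 3 `COc1ccccc1-c1csc2cnc(Nc3ccc(C(=O)NC4CCNCC4)cc3C)nc12` gives 250 nM; this is the lowest of the three numbers, though its gap to compound 2 lies within the scatter, so those two cannot be ranked against each other, while its gap to compound 1 lies beyond the scatter.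

Compound 4 `COc1ccccc1-c1csc2cnc(Nc3ccc(C(=O)NC4CCNCC4)cc3C(F)(F)F)nc12` has not yet been measured. Its structure differs from compound 3 in one place: trifluoromethyl in place of methyl on an aromatic carbon. Within the data shown here, no measured step involves this kind of change; the one single-point step available concerns the saturated ring on the other side of the molecule, so it offers no direct guide. With nothing comparable to draw on, the most defensible expectation is a change that stays within the usual scatter, in either direction. Compound 4 is therefore expected to give about 300 nM, with a likely range from 100 nM to 900 nM. The step this estimate implies is a 1.2-fold higher number from compound 3 to compound 4 (0.08 log units; within the scatter), expected to be small.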

Compound 4, half-maximal inhibitory concentration: 2090 nM
Estimate against measurement, compound 4: 7.0-fold (0.84 log units) below, and the stated range ends below it.
By their numbers in this assay, from the lowest: compounds 3 and 2 (each within the scatter of the next); then compounds 1 and 4 (each within the scatter of the next).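

In this assay, the aromatic carbon that lies ortho to a large group and meta to the (piperidin-4-yl)carbamoyl group proves sensitive to what it carries: trifluoromethyl in place of methyl gives an 8.4-fold higher number from compound 3 to compound 4 (0.92 log units; beyond the scatter). Among these compounds, the earlier single-place step concerned only the saturated ring, so this is the first sign that a change on the aromatic ring can also move the number beyond the scatter, and here it moves towards weaker inhibition. Neither group carries a hydrogen-bond donor, a hydrogen-bond acceptor or a net charge, so a step of this size can arise with those counts unchanged, although nothing measured here speaks to what lies behind it.

With only methyl and trifluoromethyl at this place, the compounds shown leave open how plain hydrogen, a chlorine atom or an ethyl group would read, and so whether the number follows the size of the group or whether trifluoromethyl is a special case. They also leave open whether the same swap would have a similar effect when the saturated ring is piperidin-3-yl rather than piperidin-4-yl.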